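Swapping One Ring Group on a Shared Core

The compounds below may be only part of what the source reports. "The series", "measured", "known", "first", "only" and "open" are said of these compounds alone.

Of the compounds shown here, three built on one shared core have been measured in a functional assay (aorta) with Rattus norvegicus as the target, in the presence of a further agent that is not named here; a higher number here means that more compound is needed for the effect, a lower number that less compound is needed. Compound 1 `COC(=O)C1=C(C)N=C(C)/C(=C(/O)OC)C1c1ccccc1OCCO[N+](=O)[O-]` gives 56 nM, compound 2 `COC(=O)C1=C(C)N=C(C)/C(=C(/O)OC)C1c1cccc(OCc2nonc2C)c1` gives 640 nM, and compound 3 `COC(=O)C1=C(C)N=C(C)/C(=C(/O)OC)C1c1ccccc1OCc1nonc1C` gives 41 nM. Compound 3 therefore sits level with compound 1, within the scatter, while compound 2 has a clearly higher number, so more of it is needed for the effect.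

Compound 4 `COC(=O)C1=C(C)N=C(C)/C(=C(/O)OC)C1c1ccccc1OCc1c(C)no[n+]1[O-]` has not been measured yet. It differs from compound 3 in one place: a group of 7 heavy atoms (3 carbon, 2 nitrogen, 2 oxygen; one five-membered aromatic ring with 3 hetero atoms) in place of a group of 6 heavy atoms (3 carbon, 2 nitrogen, 1 oxygen; one five-membered aromatic ring with 3 hetero atoms), on a saturated chain carbon bound to an oxygen on an aromatic ring. The group that leaves is 4-methyl-1,2,5-oxadiazol-3-yl, and both groups contain one five-membered aromatic ring with 3 hetero atoms and have no net charge.

For the measured compounds named here, the only measured step at this place is a 1.4-fold lower number from compound 1 to compound 3 (0.14 log units; within the scatter). That swap of one group for another left the number within the scatter. Going by the values given here, no measured compound yet carries the entering group, so this single step is a modest guide and the range must stay wide. The expected step is a 1.0-fold lower number from compound 3 to compound 4 (0.01 log units; within the scatter), with no shift beyond the scatter in either direction. In this assay, compound 4 is estimated at 40 nM, with an expected range from 12 nM to 140 nM.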

Compound 4, half-maximal effective concentration: 78 nM
The estimate for compound 4 lay 2.0-fold (0.29 log units) below the measured number, and the stated range covers the measured number.
By their numbers in this assay, from the lowest: compounds 3, 1 and 4 (each within the scatter of the next); then compound 2.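

At this place, on a saturated chain carbon bound to an oxygen on an aromatic ring, this assay now covers a third group: the entering group of 7 heavy atoms gives a 1.9-fold higher number from compound 3 to compound 4 (0.28 log units; within the scatter). Set against the group with no ring in compound 1, the same group gives a 1.4-fold higher number from compound 1 to compound 4 (0.14 log units; within the scatter), so all three groups tried at this place, two with a ring and one without, lie within the scatter of one another. No measurement shown here explains why these different groups give such close numbers.

Going by these compounds, it remains open whether a much different group at this place, such as an amine, a carboxylic acid or a longer chain, would also stay within the scatter, or would finally give a step beyond it. On these data alone, it also remains open how the group of compound 4 would behave if it were attached to the aromatic ring where the side chain of compound 2 sits, since compound 2 carries only 4-methyl-1,2,5-oxadiazol-3-yl.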